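Fluoro for nitro at the assay limit

The source may hold more compounds than are shown below. What is called first, only, known or untested is meant among the compounds shown, and "the series" means these compounds.

In a functional assay on K562 cells (Homo sapiens) for cytotoxicity, read by MTT assay, with a stated time of 24 h (on this read-out higher numbers stand for weaker inhibition and lower numbers for stronger inhibition), compound 1 `C=C1CC[C@H]2C(C)(C)CCC[C@]2(C)[C@H]1CCC(C)CC(=O)OC` gives > 200000 nM as a limit and not a number. Compound 2 `CC(CC[C@H]1/C(=C/c2ccc([N+](=O)[O-])cc2)CC[C@H]2C(C)(C)CCC[C@]12C)CC(=O)O` gives > 200000 nM as a limit too, which places compound 2 at the limit of > 200000 nM in this assay, at which 2 of the 2 values shown sit, and no more finely than that.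

Compound 3 `CC(CC[C@H]1/C(=C/c2ccc(F)cc2)CC[C@H]2C(C)(C)CCC[C@]12C)CC(=O)O` carries fluoro in place of nitro on an aromatic carbon, para to a large group, with fluoro in place of nitro on an aromatic carbon as the counted difference. Among the compounds with values here, no measured pair shows this change, so the expected move in this assay is slight and toward stronger inhibition, an estimated at least 1.1-fold lower number from compound 2 to compound 3 (0.07 log units; that floor lies within the scatter) in size. Compound 3 is estimated at 170000 nM with a range from 60000 nM to 300000 nM and may again return only a limit.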

Compound 3, half-maximal inhibitory concentration: > 200000 nM
Compound 3 ended at the assay's limit; the forecaster's own chance of this, stated with the estimate: 65%; middle value at least 1.1-fold (0.07 log units) from the limit.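

Within the data shown here, compound 2 and compound 3 both return only a limit, so no step between them can be read: the limit of > 200000 nM in this assay, at which 3 of the 3 values shown sit. Going by these compounds, whether fluoro and nitro differ at all in this assay, and what structure would give a measurable value, stays open.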